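This account rests on a few compounds, and the source may have more. Where it says the series, first, only, none or still open, it means among the compounds named here.

The three compounds measured in a functional assay on HEK293 cells for agonist activity at Bombesin receptor subtype-3 (Homo sapiens), read by luminescence and calcium flux, with a stated time of 10 min; on this read-out lower numbers stand for an effect already at smaller amounts and higher numbers for an effect only at larger amounts of compound:
compound 1, `CCC(C)(C)Cc1c[nH]c(CCc2ccc(-n3ccnn3)cc2)n1`, 641 nM
compound 2, `CCC(C)(C)Cc1c[nH]c(CCc2ccc(-c3cnccn3)cc2)n1`, 431 nM
compound 3, `CCC(C)(C)Cc1c[nH]c(CCc2ccc(-c3ccc(F)cn3)cc2)n1`, 66 nM

Compound 1 gives the highest number of the three in this assay. Its nearest neighbour is compound 2: a 1.5-fold lower number from compound 1 to compound 2 (0.17 log units; within the scatter), so these two cannot be told apart. Compound 3 stands furthest away: a 9.7-fold lower number from compound 1 to compound 3 (0.99 log units; beyond the scatter). The step of a 6.5-fold lower number from compound 2 to compound 3 (0.81 log units; beyond the scatter) is likewise beyond the scatter.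

Compound 4, `CCC(C)(C)Cc1c[nH]c(CCc2ccc(-n3cncn3)cc2)n1`, has not yet been measured. It differs from compound 1 in one place: 1H-1,2,4-triazol-1-yl in place of 1H-1,2,3-triazol-1-yl on an aromatic carbon. The same atoms are present in both; they are simply joined differently within the five-membered ring.

Among the measured compounds shown here, none of the measured steps tests a swap of this kind. For the measured compounds named here, the one step within the scatter, a 1.5-fold lower number from compound 1 to compound 2 (0.17 log units; within the scatter), exchanges a five-membered ring for a six-membered one, and the larger steps leading to compound 3 introduce a 5-fluoropyridin-2-yl group, a different sort of change altogether. The group that leaves and the group that enters match in everything that is counted. No step beyond the scatter is expected in this assay, in either direction. Compound 4 is therefore estimated to give about 550 nM, with a range from 220 nM to 1400 nM, which would amount to an expected 1.2-fold lower number from compound 1 to compound 4 (0.07 log units; within the scatter).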

Compound 4, half-maximal effective concentration: 570 nM
For compound 4 the middle estimate is 1.0-fold (0.02 log units) below the measured one; the range from low to high includes it.
By their numbers in this assay, from the lowest: compound 3; then compounds 2, 4 and 1 (each within the scatter of the next).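

Shifting one ring nitrogen within the triazole is the first swap here that keeps everything counted about the group the same, and in this assay it gives a 1.1-fold lower number from compound 1 to compound 4 (0.05 log units; within the scatter), so on this aromatic carbon, para to a large group, the two triazoles cannot be told apart. The new triazole also cannot be told apart from the pyrazin-2-yl group, with a 1.3-fold higher number from compound 2 to compound 4 (0.12 log units; within the scatter), while an 8.6-fold higher number from compound 3 to compound 4 (0.94 log units; beyond the scatter) shows that the 5-fluoropyridin-2-yl group stands clear of this triazole just as it does of the first one. Nothing at hand explains why the two triazoles read alike or why the 5-fluoropyridin-2-yl group stands apart.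

The compounds shown leave open whether that gap belongs to the fluorine or to the pyridine ring itself, a question that a plain pyridin-2-yl group would help to settle. On these data alone, it also remains open how this place would respond to a group of quite another kind, such as an amine or a carboxylic acid, in place of an aromatic ring.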